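The source may report more compounds than this note shows. Statements on the series, on what has been measured and on what is new or still open speak of the compounds shown alone.

Compound 1 `CC(C)=CCn1c(CN2CCN(C(=O)C3CC3)CC2)nc2ccccc21`: in an assay on isolated protein for inhibition of aldehyde dehydrogenase 1A1 (Homo sapiens), read by spectrophotometry, tested at 10 uM (a lower number here means less inhibition, a higher number more inhibition at the concentration tested (going by the name of the read-out)), compound 1 gives 74.3%.
Compound 2 `CCn1c(CN2CCN(C(=O)C3CC3)CC2)nc2ccccc21`: in this assay compound 2 gives 20.8%.

Within the data shown here, of these two numbers, compound 2 stands lowest; its only neighbour is compound 1, which sits well above it. Among the measured compounds shown here, the single measured step, a number 53.5 percentage points lower from compound 1 to compound 2 (beyond the scatter), came from placing methyl in place of 2-methylprop-1-en-1-yl on a saturated chain carbon bound to an aromatic nitrogen, and it is large and beyond the scatter.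

Compound 3 `O=C(C1CC1)N1CCN(Cc2nc3ccccc3n2Cc2ccccc2C(F)(F)F)CC1` has not yet been measured. It differs from compound 2 by 2-(trifluoromethyl)phenyl in place of methyl on a saturated chain carbon bound to an aromatic nitrogen. For the measured compounds named here, this change reverses the direction of the one known step: methyl again gives way to a much larger group at the same place. Since the small methyl went with the weak result of compound 2, a rise in this assay beyond the scatter is expected, though the new group is not the one that was measured, so the size is uncertain. Compound 3 is expected to give about 65%, with a likely range from 40% to 88%. The expected step is a number 44.2 percentage points higher from compound 2 to compound 3 (beyond the scatter).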

Compound 3, a percentage reported as inhibition, at one concentration (the size of the read-out at that concentration, not a potency): 56.3%
Beside the measured number, compound 3's estimate is 8.7 percentage points above it; low and high end bracket the measured number.
By their numbers in this assay, from the lowest: compound 2; then compound 3; then compound 1.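

At the saturated chain carbon bound to an aromatic nitrogen, the rise over methyl is no longer tied to the 2-methylprop-1-en-1-yl group alone: in this assay there is a number 35.5 percentage points higher from compound 2 to compound 3 (beyond the scatter), with 2-(trifluoromethyl)phenyl in place of methyl. The two replacement groups are not interchangeable, however, as there is also a number 18 percentage points lower from compound 1 to compound 3 (beyond the scatter), so an aromatic ring of carbon only recovers much of the gain over methyl but not all of it. No measured evidence here explains either step.

From the compounds shown here alone, what remains open is whether the ring or the trifluoromethyl on it accounts for the rise over methyl. Plain phenyl at this place would separate those two, while an amine or a carboxylic acid on the chain would test how far the position accepts a very different kind of group.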